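Para-Bromophenyl Replacing Ortho-Fluorophenyl on a Shared Core

This account rests on a few compounds, and the source may have more. Where it says the series, first, only, none or still open, it means among the compounds named here.

Compound 1, `COc1ccccc1Oc1c(N)nc(-c2cccc(C)c2)nc1Cl`: 13100 nM
Compound 2, `COc1ccccc1Oc1c(N)nc(-c2ccc(C)cc2)nc1Cl`: 17400 nM
Compound 3, `COc1ccccc1Oc1c(N)nc(-c2ccccc2F)nc1Cl`: 13800 nM

In a functional assay on B16 cells (Mus musculus) for cytotoxicity, read by CCK-8 assay, with a stated time of 24 h (on this read-out higher numbers stand for weaker inhibition and lower numbers for stronger inhibition), compound 3 gives 13800 nM, the second highest of the three numbers; its nearest neighbour is compound 1, and the steps of a 1.1-fold higher number from compound 1 to compound 3 (0.02 log units; within the scatter) and a 1.3-fold lower number from compound 2 to compound 3 (0.10 log units; within the scatter) both lie within the scatter. Compound 4, `COc1ccccc1Oc1c(N)nc(-c2ccc(Br)cc2)nc1Cl`, is not yet measured. It differs from compound 3 by 4-bromophenyl in place of 2-fluorophenyl on an aromatic carbon. The measured steps that bear on this change are those that alter the same aryl group: a 1.3-fold higher number from compound 1 to compound 2 (0.12 log units; within the scatter), a 1.1-fold higher number from compound 1 to compound 3 (0.02 log units; within the scatter) and a 1.3-fold lower number from compound 2 to compound 3 (0.10 log units; within the scatter), each within the scatter. Every change of this aryl group so far has left the number in this assay essentially where it was, so no step beyond the scatter is expected for compound 4, in either direction. Compound 4 is therefore estimated at 15000 nM, with a range from 7000 nM to 35000 nM. The expected step from compound 3 is a 1.1-fold higher number from compound 3 to compound 4 (0.04 log units; within the scatter).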

Compound 4, half-maximal inhibitory concentration: 4440 nM
The estimate for compound 4 lay 3.4-fold (0.53 log units) above the measured number; the whole stated range lies above it.
By their numbers in this assay, from the lowest: compound 4; then compounds 1, 3 and 2 (each within the scatter of the next).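

In this assay, the aryl group on the aromatic carbon between two ring nitrogen atoms turns out to be able to shift the number: the change to 4-bromophenyl gives a 3.1-fold lower number from compound 3 to compound 4 (0.49 log units; beyond the scatter) and a 3.0-fold lower number from compound 1 to compound 4 (0.47 log units; beyond the scatter). The most direct comparison is bromo in place of methyl on the same phenyl carbon, which gives a 3.9-fold lower number from compound 2 to compound 4 (0.59 log units; beyond the scatter), so compound 4 stands alone as the strongest of the four, while compounds 1, 2 and 3 remain within the scatter of one another. No measurement shown here accounts for this difference between bromo and methyl.

On these data alone, it remains open whether 4-chlorophenyl or 4-methoxyphenyl would give a number like that of compound 4 or that of compound 2. The compounds shown also leave open whether 3-bromophenyl or 2-bromophenyl would keep the step.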